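Three Inactive Amides and an Amine Analogue Awaiting Test

The source may hold more compounds than are shown below. What is called first, only, known or untested is meant among the compounds shown, and "the series" means these compounds.

Measured compounds:
compound 1, `O=C(CCCNC(=O)c1cc(C(F)(F)F)cc(C(F)(F)F)c1)Nc1ccc(Cl)cc1`: 0%
compound 2, `O=C(Nc1ccc(Cl)cc1)C1CCCN1C(=O)c1cc(C(F)(F)F)cc(C(F)(F)F)c1`: 0%
compound 3, `O=C(CONC(=O)c1ccc(C(F)(F)F)cc1)Nc1ccc(Cl)cc1`: 0%

Of the compounds shown here, three have been measured in a functional assay on PC-3 cells (Homo sapiens) for inhibition, read by WST assay, tested at 10 uM; on this read-out lower numbers stand for a weaker effect and higher numbers for a stronger effect at the one concentration tested. Compound 1, `O=C(CCCNC(=O)c1cc(C(F)(F)F)cc(C(F)(F)F)c1)Nc1ccc(Cl)cc1`, gives 0%. Compound 2, `O=C(Nc1ccc(Cl)cc1)C1CCCN1C(=O)c1cc(C(F)(F)F)cc(C(F)(F)F)c1`, gives 0%. Compound 3, `O=C(CONC(=O)c1ccc(C(F)(F)F)cc1)Nc1ccc(Cl)cc1`, gives 0%. At the digits reported, compound 1 stands level with compound 2 and with compound 3; the nearest to it is compound 2, with no change at the digits reported and within the scatter, and the furthest is compound 3, again with no change at the digits reported and within the scatter. Among the measured compounds shown here, none of the pairs differs in a single place, so no step between measured compounds can be stated.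

Compound 4, `O=C(NCCCNc1ccc(Cl)cc1)c1cc(C(F)(F)F)cc(C(F)(F)F)c1`, has not yet been measured in this assay. It differs from compound 1 as follows: (4-chlorophenyl)amino in place of (4-chlorophenyl)carbamoyl on a saturated chain carbon, three bonds along the chain from an amide-type nitrogen. For the measured compounds named here, since every measured compound shows no effect in this assay, and no step indicates which changes raise the read-out, the step from compound 1 to compound 4 is expected to be none beyond the scatter, as a number 5 percentage points higher from compound 1 to compound 4 (within the scatter). Compound 4 is accordingly estimated at 5%, with a range from 0% to 25%.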

Compound 4, a percentage reported as inhibition, at one concentration (the size of the read-out at that concentration, not a potency): 0%
Beside the measured number, compound 4's estimate is 5 percentage points above it; the measured number falls inside the stated range.
By their numbers in this assay, from the lowest: compounds 1, 2, 3 and 4 (each within the scatter of the next).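

In this assay, among the compounds shown here, (4-chlorophenyl)amino in place of (4-chlorophenyl)carbamoyl on a saturated chain carbon, three bonds along the chain from an amide-type nitrogen, gives no change at the digits printed from compound 1 to compound 4 (within the scatter), the first single-place step that can be read in this set. At this place, then, the read-out stays the same with or without the carbonyl of the group that leaves, but as neither compound shows any effect, the step cannot tell whether the same change would matter in a compound that does show one. No measurement shown here bears on this result.

Since all the compounds shown give the same read-out, they leave open which change, if any, would raise it at the one concentration tested. Whether a longer chain, a carboxylic acid on the chain, or a pyridine ring in place of the 4-chlorophenyl ring would move the read-out remains an open question.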